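The compounds below may be only part of what the source reports. "The series", "measured", "known", "first", "only" and "open" are said of these compounds alone.

Measured in a functional assay on Jurkat cells (Homo sapiens); a higher number here means a weaker inhibitor, a lower number a stronger inhibitor:
- compound 1 `CC(C)[C@H](NC(=O)COc1cccc2ccccc12)C(=O)N[C@@H](CC(=O)O)C(=O)COc1ccc(C(F)(F)F)cc1`: > 100000 nM
- compound 2 `CC(C)[C@H](NC(=O)COc1cccc2ccccc12)C(=O)N[C@@H](CC(=O)O)C(=O)COc1cc(C(F)(F)F)cc(C(F)(F)F)c1`: > 100000 nM
- compound 3 `CC(C)[C@H](NC(=O)COc1cccc2ccccc12)C(=O)N[C@@H](CC(=O)O)C(=O)COc1ccc(Oc2ccccc2)cc1`: 12700 nM

Compound 1 sits at the limit of > 100000 nM in this assay, at which 2 of the 3 values shown sit, so its position is known only as a limit. Compound 2 also gives only a limit, > 100000 nM. Compound 3 alone has a true number, 12700 nM.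

Compound 4 `CC(C)[C@H](NC(=O)COc1cccc2ccccc12)C(=O)N[C@@H](CC(=O)O)C(=O)COc1cccc(F)c1` has not yet been measured. It carries 3-fluorophenyl in place of the 4-(trifluoromethyl)phenyl of compound 1, on an oxygen on a saturated carbon: 3-fluorophenyl in place of 4-(trifluoromethyl)phenyl on an oxygen on a saturated carbon.

Among the measured compounds shown here, one measured step bears on this change: an at least 7.8-fold lower number from compound 1 to compound 3 (0.89 log units; beyond the scatter). It shows that a change on this same aromatic group can move the number beyond the scatter. However, the phenoxy group of compound 3 has no counterpart in compound 4, so only part of that gain is expected to carry over, and a reading at the limit remains possible.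

The expected change is an at least 2.2-fold lower number from compound 1 to compound 4 (0.34 log units; beyond the scatter), towards a lower number in this assay. For compound 4 the estimate is 45000 nM, with an expected range of 12000 nM to 100000 nM.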

Compound 4, half-maximal inhibitory concentration: > 100000 nM
Compound 4 gave a limit, no number; the forecaster's own chance of this, stated with the estimate: 45%; middle value at least 2.2-fold (0.34 log units) away from the limit.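

In this assay compound 4 gives > 100000 nM, a limit and not a number. Among the compounds shown here, compound 1 also gives only a limit, so no step between compound 1 and compound 4 can be read: the limit of > 100000 nM in this assay, at which 3 of the 4 values shown sit. The compounds shown leave open how 3-fluorophenyl and 4-(trifluoromethyl)phenyl compare in this assay.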